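One stereocentre inverted: compound 2 to compound 3

The source may hold more compounds than are shown below. What is called first, only, known or untested is meant among the compounds shown, and "the series" means these compounds.

In a functional assay on SW480 cells (Homo sapiens) for cytotoxicity, read by MTT assay, with a stated time of 48 h (on this read-out higher numbers stand for weaker inhibition and lower numbers for stronger inhibition), compound 1 (`CCOC(=O)[C@@]1(C(=O)Nc2ccccc2)C[C@@H]1c1cc(OC)c(OC)c(OC)c1`) gives > 100000 nM as a limit of the assay, not a number. Compound 2 (`CCOC(=O)[C@@]1(C(=O)NCc2ccc(C)cc2)C[C@H]1c1cc(OC)c(OC)c(OC)c1`) gives > 100000 nM as a limit too, so it offers no number to step from. Among the compounds with values here, the series so far sits at one place (the limit of > 100000 nM in this assay, at which 2 of the 2 values shown sit). Compound 3 (`CCOC(=O)[C@@]1(C(=O)NCc2ccc(C)cc2)C[C@@H]1c1cc(OC)c(OC)c(OC)c1`) is related to compound 2 by the two compounds have the same atoms and bonds and differ only in configuration as drawn: 1 of 2 stereo elements differ; a stereocentre at a saturated ring carbon is drawn S in compound 2 and R in compound 3 with the saturated ring carbon drawn R in compound 3 and S in compound 2. Within the data shown here, no measured step covers such a change, so nothing beyond the scatter is expected in this assay. The expected step is an at least 1.1-fold lower number from compound 2 to compound 3 (0.04 log units; that floor lies within the scatter) in size. Compound 3 is expected at 90000 nM within an estimated range of 25000 nM to 150000 nM and may well read as a limit again.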

Compound 3, half-maximal inhibitory concentration: > 100000 nM
Compound 3: only a limit was reported (the forecaster's own chance of this, stated with the estimate: 75%); middle value at least 1.1-fold (0.04 log units) away from the limit.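

Compound 3 also reads as a limit, so its steps from compound 1 and compound 2 cannot be read: the limit of > 100000 nM in this assay, at which 3 of the 3 values shown sit. As far as these compounds go, whether the configuration drawn in compound 2 and compound 3 affects the read-out in this assay stays open.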